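The source may report more compounds than this note shows. Statements on the series, on what has been measured and on what is new or still open speak of the compounds shown alone.

Values in a functional assay on HEK293 cells (Homo sapiens) for cytotoxicity (on this read-out lower numbers stand for higher toxicity in this test and higher numbers for lower toxicity in this test), follow, each of them a limit:
- compound 1 `COc1ccc([C@H]2CC(=O)N(c3cccc(N(C)C)c3)C2)cc1OC1CCCC1` gives > 10000 nM as a limit
- compound 2 `COc1ccc([C@H]2CC(=O)N(c3cccc(C(F)(F)F)c3)C2)cc1OC1CCCC1` gives > 10000 nM as a limit
- compound 3 `COc1ccc([C@H]2CC(=O)N(c3cccc(NCCCc4ccccc4)c3)C2)cc1OC1CCCC1` gives > 10000 nM as a limit

Compound 3 stands at > 10000 nM as a limit and not a number, so it cannot be ranked against the other two compounds. Compound 4 `COc1ccc(S(=O)(=O)Nc2cccc(N3C[C@@H](c4ccc(OC)c(OC5CCCC5)c4)CC3=O)c2)cc1` carries (4-methoxyphenyl)sulfonyl in place of 3-phenylpropyl on a nitrogen on an aromatic ring. For the measured compounds named here, three measured steps bear on this substituent: a step that the two limits leave unreadable from compound 1 to compound 2 and a step that the two limits leave unreadable from compound 1 to compound 3 and a step that the two limits leave unreadable from compound 2 to compound 3 all come without a readable size. The whole record so far is the limit of > 10000 nM in this assay, at which 3 of the 3 values shown sit, and gives neither a size nor a direction to carry over. Compound 4 is therefore expected to show no step beyond the scatter in this assay and most likely to be reported as a limit too because of the limit of > 10000 nM in this assay, at which 3 of the 3 values shown sit, alone. The expected change is a step that the limit leaves unreadable from compound 3 to compound 4 and it remains an estimate with no direction read from the data. The estimated value for compound 4 is 20000 nM (expected range 6000 nM to 60000 nM).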

Compound 4, half-maximal cytotoxic concentration: > 10000 nM
Compound 4: a limit, no number; the forecaster's own chance of this, stated with the estimate: 85%; the middle value lies beyond the limit too.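

In this assay, the steps joining compound 4 to compound 1, compound 2 and compound 3 cannot be read, and none of them gives a size or a direction: the limit of > 10000 nM in this assay, at which 4 of the 4 values shown sit.

The compounds shown leave open where the actual values of all four lie in this assay, and whether any of these substituents separates them.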